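The source may report more compounds than this note shows. Statements on the series, on what has been measured and on what is new or still open speak of the compounds shown alone.

Among the measured compounds shown here, compound 2, `CCOC(=O)C(=O)NC1=C(C#N)C2C(N3CCCC3)CCCCN2C(=O)N1c1ccccc1`, is one of two compounds measured in a functional assay on the whole organism (strain albino) for inhibition, with Rattus norvegicus as the target, read by paw edema, with stated times of 1 h and 3 h, at a dose of 24 mmol/kg by the intraperitoneal route; a lower number here means a weaker effect, a higher number a stronger effect of the compound at the dose given. In this assay compound 2 gives 92.4%, the highest of the two numbers, and the nearest is compound 1, `N#CC1=C(NCC(=O)O)N(c2ccccc2)C(=O)N2CCCCC(N3CCCC3)C12`, which in this assay gives 91.4%; the two stand within the scatter of each other, so no order between them is claimed. For the measured compounds named here, the only measured step, a number 1 percentage points higher from compound 1 to compound 2 (within the scatter), is the exchange of one group on an amine nitrogen for another and it left the read-out essentially unchanged.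

Compound 3, `N#CC1=C(/N=C/c2ccc([N+](=O)[O-])cc2)N(c2ccccc2)C(=O)N2CCCCC(N3CCCC3)C12`, is not yet measured. It differs from compound 2 as follows: a group of 11 heavy atoms (7 carbon, 2 nitrogen, 2 oxygen; one six-membered aromatic ring of carbon only) in place of a group of 8 heavy atoms (4 carbon, 1 nitrogen, 3 oxygen; no ring), on a double-bonded ring carbon. Going by the values given here, the earlier step concerned the same place on the core and was within the scatter, which is the only guide here; the entering group has no direct precedent among the measured compounds, so the change carries more uncertainty. A step near zero or a modest fall is therefore expected, a number 6.4 percentage points lower from compound 2 to compound 3 (within the scatter). For compound 3 the estimate in this assay is 86%, expected to fall between 66% and 97%.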

Compound 3, a percentage reported as inhibition, in the whole organism at one dose (the size of the read-out at that dose, not a potency): 90.8%
For compound 3 the middle estimate is 4.8 percentage points below the measured one, within the range that was stated.
By their numbers in this assay, from the lowest: compounds 3, 1 and 2 (each within the scatter of the next).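

At this place, on a double-bonded ring carbon, the earlier pair had shown only that two open-chain groups gave readings within the scatter of each other in this assay; compound 3 extends this to an entering group with one six-membered aromatic ring of carbon only, with a number 1.6 percentage points lower from compound 2 to compound 3 (within the scatter) and a number 0.6 percentage points lower from compound 1 to compound 3 (within the scatter). Against the ((ethoxycarbonyl)carbonyl)amino group of compound 2, the entering group has more heavy atoms and 0 hydrogen-bond donors, yet neither difference comes with a step beyond the scatter at the one dose given. No measurement is available here that could explain this outcome.

The three compounds leave open whether a plain amine or a longer alkyl chain at this place would also stay within the scatter, or whether any group here can move the read-out beyond it. They also leave open what replacing the cyano group or the phenyl group would do, and, as each number is the size of the effect at a single dose, whether the compounds would still read alike at other doses.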